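Dropping the Methoxy from Compound 1

This account rests on a few compounds, and the source may have more. Where it says the series, first, only, none or still open, it means among the compounds named here.

Compound 1 `COc1ccccc1NC(=S)N/N=C/c1ccc2ccccc2n1` reaches only the limit > 100000 nM in a functional assay on SGC-7901 cells (Homo sapiens) for antiproliferative activity, read by sulforhodamine B assay, with a stated time of 72 h; on this read-out lower numbers stand for stronger inhibition and higher numbers for weaker inhibition.
Compound 2 `NC(=S)N/N=C/c1nc2ccccc2s1` likewise sits at the limit > 100000 nM in this assay.
Compound 3 `NC(=S)N/N=C/c1ccc2ccccc2n1` gives 32700 nM in this assay.

Compound 1 therefore stands at a limit of the assay rather than at a measured number, and it is not alone there (the limit of > 100000 nM in this assay, at which 2 of the 3 values shown sit). Compound 4 `S=C(N/N=C/c1ccc2ccccc2n1)Nc1ccccc1` differs from compound 1 in one place, (hydrogen in place of methoxy on an aromatic carbon); cut one bond further out, the same change reads 2-methoxyphenyl to phenyl.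

Among the compounds with values here, only one measured step bears on this region of the molecule: an at least 3.0-fold lower number from compound 1 to compound 3 (0.48 log units; beyond the scatter). That step removed the whole 2-methoxyphenyl from the amide-type nitrogen and brought the number down from the limit to a measured value. Compound 4 keeps the phenyl and sheds only the methoxy, a smaller change than the one measured, so the author expects the step to be smaller as well, in the same downward direction at most, and quite possibly not beyond the scatter, with a real chance that compound 4 again returns only a limit. The expected step is an at least 1.1-fold lower number from compound 1 to compound 4 (0.04 log units; that floor lies within the scatter). For compound 4 in this assay the estimate is 90000 nM, within a range from 30000 nM to 300000 nM.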

Compound 4, half-maximal inhibitory concentration: 26500 nM
Beside the measured number, compound 4's estimate is 3.4-fold (0.53 log units) above it; the whole stated range lies above it.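

Taking off the methoxy alone in this assay gives an at least 3.7-fold lower number from compound 1 to compound 4 (0.57 log units; beyond the scatter), so this single change on an aromatic carbon, ortho to a large group, is enough to move the read-out from a limit to a measured number. Putting phenyl on the amide-type nitrogen gives a 1.2-fold lower number from compound 3 to compound 4 (0.09 log units; within the scatter), which lies within the scatter, so hydrogen and phenyl at that nitrogen are not told apart here, whereas the earlier step had removed the whole 2-methoxyphenyl and could not separate the methoxy from the ring that carries it. The present pair places the change with the methoxy, but its size remains only a floor, since compound 1 stands at a limit and not at a measured number: the limit of > 100000 nM in this assay, at which 2 of the 4 values shown sit.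

The compounds shown leave open whether the methoxy is a special case or whether another group on that aromatic carbon, such as a hydroxyl, a chlorine atom or an amine, would keep the number near that of compound 4 or return it to the limit. They also leave open how far the true value of compound 1 lies from the limit, and so how large the step really is.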